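The source may report more compounds than this note shows. Statements on the series, on what has been measured and on what is new or still open speak of the compounds shown alone.

Measured compounds:
- compound 1 `CC(C)Oc1cc(C(=O)N(C)C)nn1-c1ccccc1` — in a functional assay on the whole organism (strain Wistar) for inhibition, with Rattus norvegicus as the target, read by paw edema, with stated times of 30 min and 3 h, at a dose of 100 mg/kg by the oral route (on this read-out lower numbers stand for less inhibition and higher numbers for more inhibition at the one dose given (going by the name of the read-out)), compound 1 gives 43.9%
- compound 2 `CCCCOc1cc(C(=O)N(C)C)nn1-c1ccccc1` — in this assay compound 2 gives 18.7%

Within the data shown here, compound 2 stands lowest of the two numbers in this assay; its nearest neighbour is compound 1, and the only measured step, a number 25.2 percentage points lower from compound 1 to compound 2 (beyond the scatter), came with butyl in place of isopropyl on an oxygen on an aromatic ring.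

Compound 3 `CCCCOc1cc(C(=O)N2CCCCC2)nn1-c1ccccc1` is not yet measured. It differs from compound 2 by piperidin-1-yl in place of dimethylamino on a carbonyl carbon. Among the measured compounds shown here, no measured step touches the amide side of the shared core; the one step known concerns the ether chain, so nothing in the numbers so far bears directly on this change. For the measured compounds named here, with no comparable step to lean on, the expectation for this assay is a step of no particular direction, most likely within the scatter, that is a number 1.3 percentage points higher from compound 2 to compound 3 (within the scatter). Compound 3 is therefore estimated at 20%, with a range from 5% to 40%.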

Compound 3, a percentage reported as inhibition, in the whole organism at one dose (the size of the read-out at that dose, not a potency): 15.6%
The estimate for compound 3 lay 4.4 percentage points above the measured number, and the stated range covers the measured number.
By their numbers in this assay, from the lowest: compounds 3 and 2 (each within the scatter of the next); then compound 1.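

In this assay, the amide side of the shared core now has its first measured step: a number 3.1 percentage points lower from compound 2 to compound 3 (within the scatter), with piperidin-1-yl in place of dimethylamino on a carbonyl carbon. Among these compounds, with butyl on the oxygen, this change from an open dimethylamino group to a six-membered ring therefore does not separate the two compounds, while the ether step, a number 25.2 percentage points lower from compound 1 to compound 2 (beyond the scatter), remains the only step beyond the scatter. No evidence on the reason for either step is available.

As far as these compounds go, whether piperidin-1-yl on the carbonyl carbon would read the same with isopropyl rather than butyl on the oxygen remains open. The compounds shown also leave open how a morpholin-4-yl group, or a carboxylic acid in place of the amide, would read at this position.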